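Swapping an aryl group on a coumarin-pyrimidine scaffold

The compounds below may be only part of what the source reports. "The series", "measured", "known", "first", "only" and "open" are said of these compounds alone.

The compounds here share a core built from a hydroxylated coumarin joined to a pyrimidine, and they were examined in an ADME assay on WI-38 cells (Homo sapiens) for cytotoxicity, read by MTT assay; on this read-out higher numbers stand for weaker inhibition and lower numbers for stronger inhibition. Compound 1 `COc1cccc(-c2cc(-c3c(O)c4ccccc4oc3=O)nc(O)n2)c1` is recorded as "not determined" (no result reported) in this assay. Compound 2 `O=c1oc2ccccc2c(O)c1-c1cc(-c2ccc(F)cc2)nc(O)n1` gives 37800 nM in this assay, a weak effect on cell viability. Among the compounds with values here, compound 3 `COc1cccc(-c2cc(-c3c(O)c4ccccc4oc3=O)nc(S)n2)c1` is recorded as "not determined" (no result reported) in this assay, so no measured footing exists for it; compound 1 is the second entry without a number, and no step between two measured compounds is available. Compound 4 `O=c1oc2ccccc2c(O)c1-c1cc(-c2c(F)cccc2Cl)nc(S)n1` differs from compound 3 in one place: 2-chloro-6-fluorophenyl in place of 3-methoxyphenyl on an aromatic carbon. Within the data shown here, with no measured step to lean on, the expectation for this change in this assay is a shift of no more than the usual scatter, in no particular direction, since the only number in the set, that of compound 2, is far from potent. Compound 4 is therefore expected to show roughly 40000 nM, within a range from 15000 nM to 110000 nM.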

Compound 4, half-maximal inhibitory concentration: 30500 nM
Compound 4: the middle estimate sits 1.3-fold (0.12 log units) above what was measured; low and high end bracket the measured number.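

In this assay, within the data shown here, compound 3 has no single number, so no step to compound 4 can be read. The shown compounds leave open what replacing 3-methoxyphenyl with 2-chloro-6-fluorophenyl does to this read-out. No supporting information bears on the result for compound 4.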